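Replacing the Aryl Group on the Shared Core of Compound 1

The source may report more compounds than this note shows. Statements on the series, on what has been measured and on what is new or still open speak of the compounds shown alone.

Of the compounds shown here, two have been measured in an assay on CHO cells for displacement of a labelled ligand from corticotropin-releasing factor receptor 1 (Homo sapiens); on this read-out higher numbers stand for weaker inhibition and lower numbers for stronger inhibition. Compound 1, `CCOc1ccc(N2CCc3c(-n4ccc(N5CCNC5=O)n4)cc(C)nc32)c(C)c1`, gives 316 nM in this assay, the lowest of the two numbers. Compound 2, `Cc1cc(-n2ccc(N3CCNC3=O)n2)c2c(n1)N(c1ccc(OC(C)C)cc1C)CC2`, gives 1230 nM in this assay. For the measured compounds named here, the only measured step, a 3.9-fold higher number from compound 1 to compound 2 (0.59 log units; beyond the scatter), concerns a change on the ether part of the aryl group and shows that a modest change there can move the number beyond the scatter.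

Compound 3, `CCc1cc(C#N)ccc1N1CCc2c(-n3ccc(N4CCNC4=O)n3)cc(C)nc21`, has not been measured in this assay. It differs from compound 1 by 4-cyano-2-ethylphenyl in place of 4-ethoxy-2-methylphenyl on a nitrogen on an aromatic ring in a ring. Going by the values given here, no measured step covers this change: the aryl group is rebuilt at two places, and nothing among the two compounds shows what a nitrile or an ethyl group at these places does. The step from compound 1 to compound 2 only shows that this assay responds to changes on the aryl group. Among the compounds with values here, with no direct precedent, no step beyond the scatter is expected in either direction, but the range is kept wide. The estimated step is a 1.3-fold higher number from compound 1 to compound 3 (0.10 log units; within the scatter). Compound 3 is expected to give about 400 nM in this assay, within a range from 100 nM to 2000 nM.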

Compound 3, half-maximal inhibitory concentration: 50.1 nM
For compound 3 the middle estimate is 8.0-fold (0.90 log units) above the measured one; the whole stated range lies above it.
By their numbers in this assay, from the lowest: compound 3; then compound 1; then compound 2.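

In this assay, exchanging 4-ethoxy-2-methylphenyl for 4-cyano-2-ethylphenyl on the nitrogen of the shared core gives a 6.3-fold lower number from compound 1 to compound 3 (0.80 log units; beyond the scatter) and so moves the number towards stronger inhibition, which shows that this position accepts an aryl group with no ether oxygen on it. For the compounds shown here, the only earlier step, a 3.9-fold higher number from compound 1 to compound 2 (0.59 log units; beyond the scatter), changed the ether alone and pointed towards weaker inhibition, so the earlier compounds showed only that the number could rise through a change on this aryl group, while compound 3 shows that it can also fall well beyond the scatter. Nothing measured here explains the gain in binding, and the two places on the aryl group changed together, so no share of the step can be given to the nitrile or to the ethyl group.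

A compound that keeps the methyl group of compound 1 and carries the nitrile in place of the ethoxy group would begin to separate the two changes. Also open, as far as these compounds go, is how the number responds when the nitrile gives way to an amine, a carboxylic acid or a chlorine atom, or when the ethyl group gives way to a longer chain.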